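This account rests on a few compounds, and the source may have more. Where it says the series, first, only, none or still open, it means among the compounds named here.

Measured so far:
compound 1, `O=C(O)CC/C=C\CC1COC(c2ccccc2Cl)OC1c1cccnc1`: 759 nM
compound 2, `N#Cc1ccc(C2OCC(C/C=C\CCC(=O)O)C(c3cccnc3)O2)cc1`: 1290 nM
compound 3, `N#Cc1ccccc1C1OCC(C/C=C\CCC(=O)O)C(c2cccnc2)O1`: 245 nM

In a functional assay for inhibition, with Homo sapiens as the target (on this read-out higher numbers stand for weaker binding and lower numbers for tighter binding), compound 3 stands lowest of the three. Its nearest neighbour is compound 1, separated by a 3.1-fold lower number from compound 1 to compound 3 (0.49 log units; beyond the scatter); the furthest is compound 2, separated by a 5.3-fold lower number from compound 2 to compound 3 (0.72 log units; beyond the scatter). Both steps lie beyond the scatter, so compound 3 is the tightest binder of the set on this read-out.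

Compound 4, `O=C(O)CC/C=C\CC1COC(c2ccc(C(F)(F)F)cc2)OC1c1cccnc1`, is not yet measured. It differs from compound 3 in one place: 4-(trifluoromethyl)phenyl in place of 2-cyanophenyl on a saturated ring carbon. The step that bears most directly on this change is a 5.3-fold lower number from compound 2 to compound 3 (0.72 log units; beyond the scatter), where 4-cyanophenyl in place of 2-cyanophenyl carried a modest penalty. The entering 4-(trifluoromethyl)phenyl resembles the 4-cyanophenyl of compound 2 more than the 2-cyanophenyl of compound 3, so a return toward the number of compound 2 is the natural expectation. The step of a 1.7-fold higher number from compound 1 to compound 2 (0.23 log units; within the scatter), within the scatter, shows that 4-cyanophenyl and 2-chlorophenyl sit close, which places the expected value for compound 4 in the region of compound 1 and compound 2. Going by the values given here, no trifluoromethyl analogue exists in the set, so the size of the step is uncertain. Compound 4 is expected to show a 3.9-fold higher number from compound 3 to compound 4 (0.59 log units; beyond the scatter), a modest rise beyond the scatter. The estimate for compound 4 is 950 nM, with a range of 400 nM to 2500 nM.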

Compound 4, dissociation constant: 1780 nM
For compound 4 the middle estimate is 1.9-fold (0.27 log units) below the measured one, within the range that was stated.
By their numbers in this assay, from the lowest: compound 3; then compounds 1, 2 and 4 (each within the scatter of the next, the first and the last beyond it).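

In this assay, a second group carrying a substituent in its name's 4-position, here without a nitrile, gives a 7.3-fold higher number from compound 3 to compound 4 (0.86 log units; beyond the scatter), so the low number of compound 3 is not shared by 4-(trifluoromethyl)phenyl at this saturated ring carbon between the two ring oxygen atoms. Exchanging the nitrile for trifluoromethyl on the aromatic carbon gives a 1.4-fold higher number from compound 2 to compound 4 (0.14 log units; within the scatter), which is within the scatter, so compound 2 and compound 4 cannot be told apart and the nitrile of the 4-cyanophenyl group makes no readable difference here. The new compound also separates from the 2-chlorophenyl compound, with a 2.3-fold higher number from compound 1 to compound 4 (0.37 log units; beyond the scatter), so both 2-substituted phenyl compounds now lie beyond the scatter from compound 4, although compound 1 and compound 2 remain within the scatter of each other and stand against a clean split by substituent location.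

The compounds shown leave open how an unsubstituted phenyl would compare at this carbon. They also leave open whether a methoxy group or an amine on the phenyl would stay near compound 3 or near compound 4.

Nothing on hand accounts for these gaps.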